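The source may hold more compounds than are shown below. What is called first, only, known or untested is meant among the compounds shown, and "the series" means these compounds.

Compound 1 `COc1cc(/C=C/C(=O)c2cccc(-n3cc(-c4ccc(Cl)cc4)[nH]c3=O)c2)cc(OC)c1OC` shares its core with compound 2 `O=C(/C=C/c1cccc(O)c1)c1cccc(-n2cc(-c3ccccc3)[nH]c2=O)c1` and compound 3 `O=C(/C=C/c1cccc(O)c1)c1cccc(-n2cc(-c3ccc(Cl)cc3)[nH]c2=O)c1`. Among the compounds with values here, in a functional assay on HOP-62 cells (Homo sapiens) for inhibition (a higher number here means a weaker inhibitor of growth, a lower number a stronger inhibitor of growth), compound 2 gives 6930 nM and compound 3 gives 2360 nM; the step between them, a 2.9-fold lower number from compound 2 to compound 3 (0.47 log units; beyond the scatter), is the only measured step in this set. Compound 1, in this assay, is reported as "not active" (no number reported), so no single number places it among the others. Compound 4 `COc1cc(/C=C/C(=O)c2cccc(-n3cc(-c4cc(OC)c(OC)c(OC)c4)[nH]c3=O)c2)cc(OC)c1OC` differs from compound 1 by 3,4,5-trimethoxyphenyl in place of 4-chlorophenyl on an aromatic carbon. Within the data shown here, no measured step touches this exchange, and a 2.9-fold lower number from compound 2 to compound 3 (0.47 log units; beyond the scatter) concerns a different group, so no direction can be drawn from the data. Starting from an inactive parent, compound 4 is expected to give 12000 nM, estimated between 2000 nM and 70000 nM, with a real chance that only a limit is reported again.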

Compound 4, concentration for 50% growth inhibition: 3080 nM
Beside the measured number, compound 4's estimate is 3.9-fold (0.59 log units) above it; measured number inside the range.
By their numbers in this assay, from the lowest: compounds 3 and 4 (each within the scatter of the next); then compound 2.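

In this assay, within the data shown here, compound 1 stands as "not active" (no number reported) while compound 4 gives 3080 nM, so no step between them can be read. Nothing shown offers an explanation for this result. As far as these compounds go, what exchanging 4-chlorophenyl for 3,4,5-trimethoxyphenyl does to the number stays open.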